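The source may hold more compounds than are shown below. What is called first, only, known or untested is meant among the compounds shown, and "the series" means these compounds.

Compound 1 `CNc1nc(C)c(C(=O)N/N=C/c2ccccc2C(F)(F)F)s1` gives > 100 ug/mL in a functional assay on BCG823 cells (Homo sapiens) for inhibition, read by MTT assay, with a stated time of 72 h (on this read-out lower numbers stand for stronger inhibition and higher numbers for weaker inhibition), which is a limit of the assay rather than a number.
Compound 2 `CN(C(=O)NC(=O)c1ccc([N+](=O)[O-])cc1)c1nc(C(F)(F)F)c(C(=O)N/N=C/c2ccc([N+](=O)[O-])cc2)s1` gives 7.45 ug/mL in this assay.
Compound 3 `CN(C(=O)NC(=O)c1ccc(C(F)(F)F)cc1)c1nc(C(F)(F)F)c(C(=O)N/N=C/c2cccc(C(F)(F)F)c2)s1` gives 1.84 ug/mL in this assay.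

Of the two compounds with a number, compound 2 stands at the higher, weaker end, and the gap to compound 3 lies beyond the usual scatter. Compound 4 `CN(C(=O)NC(=O)c1ccc(Cl)c(Cl)c1)c1nc(C(F)(F)F)c(C(=O)N/N=C/c2ccc([N+](=O)[O-])cc2)s1` differs from compound 2 by a single change: 3,4-dichlorophenyl in place of 4-nitrophenyl on a carbonyl carbon. Among the compounds with values here, no pair of measured compounds differs by this change alone, so its effect is untested here. The step from compound 2 to compound 4 is expected to be small, a 1.4-fold lower number from compound 2 to compound 4 (0.13 log units; within the scatter), and not clearly beyond the scatter in either direction. Compound 4 is therefore estimated at 5.5 ug/mL, with a likely range from 1.8 ug/mL to 17 ug/mL.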

Compound 4, half-maximal inhibitory concentration: 2.13 ug/mL
Compound 4: middle estimate off by 2.6-fold (0.41 log units), on the high side, and the stated range covers the measured number.
By their numbers in this assay, from the lowest: compounds 3 and 4 (each within the scatter of the next); then compound 2. At a limit, above all of these: compound 1.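

In this assay the swap of 4-nitrophenyl for 3,4-dichlorophenyl on this carbonyl carbon gives a 3.5-fold lower number from compound 2 to compound 4 (0.54 log units; beyond the scatter), so the group at this place can move the number by more than repeat measurements would. This rests on a single pair and sets no trend for other groups. Nothing measured here accounts for the change. Still open, going by these compounds, is whether a plain phenyl, or a phenyl carrying an amine or a carboxylic acid, would lower the number further or raise it. Also open, on these data alone, is whether the same swap gives a similar step when the other 4-nitrophenyl group is replaced.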